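The source may report more compounds than this note shows. Statements on the series, on what has been measured and on what is new or still open speak of the compounds shown alone.

Working notes on the series. In a physicochemical assay for solubility, with a stated time of 1 h, at pH 1.6 (on this read-out lower numbers stand for lower solubility and higher numbers for higher solubility), compound 1 `Cc1c(Cc2ccc(C(F)(F)F)nc2)c[nH]c1C(=O)NC(C)c1cnn(C)c1` gives 113 ug/mL, while compound 2 `Cc1c(C2(c3ccc(C(F)(F)F)nc3)CC2)c[nH]c1C(=O)NC(C)c1nc[nH]n1` gives 1030 ug/mL. Compound 1 therefore holds the lower of the two numbers, and its gap to compound 2 lies beyond the usual scatter. Within the data shown here, these two compounds differ in more than one place, so no measured pair isolates a single change. The unmeasured compound 3 `Cc1c(Cc2ccc(C(F)(F)F)nc2)c[nH]c1C(=O)NC(C)c1cn[nH]c1` keeps the core of compound 1 and alters one group: hydrogen in place of methyl on an aromatic nitrogen, taking 1-methyl-1H-pyrazol-4-yl to 1H-pyrazol-4-yl. Among the measured compounds shown here, with no measured step to serve as a guide, a modest upward move in this assay is expected, possibly none beyond the scatter. The expected step is a 1.7-fold higher number from compound 1 to compound 3 (0.23 log units; within the scatter). The estimate for compound 3 is 190 ug/mL, with an expected range of 60 ug/mL to 600 ug/mL.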

Compound 3, solubility: 81 ug/mL
Compound 3: middle estimate off by 2.3-fold (0.37 log units), on the high side; low and high end bracket the measured number.
By their numbers in this assay, from the lowest: compounds 3 and 1 (each within the scatter of the next); then compound 2.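

Hydrogen in place of methyl on an aromatic nitrogen, taking 1-methyl-1H-pyrazol-4-yl to 1H-pyrazol-4-yl, gives a 1.4-fold lower number from compound 1 to compound 3 (0.14 log units; within the scatter) in this assay. Among these compounds, this is the first step that isolates one change, and at this position the read-out does not separate methyl from hydrogen. Nothing on hand offers an explanation for this result.

Still open, from the compounds shown here alone, is whether another group on this aromatic nitrogen, such as an ethyl chain or a chain ending in an amine or a carboxylic acid, would give a step beyond the scatter. Compound 2 differs from compound 1 and compound 3 in more than one place, so the compounds shown do not tie its number to any single difference.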